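Shortening an Alkoxy Group on a Shared Kinase Inhibitor Core

The source may report more compounds than this note shows. Statements on the series, on what has been measured and on what is new or still open speak of the compounds shown alone.

Compound 1 `CC(C)Oc1ccc2c(c1)CC(c1nc3ccc(-c4ccnc(N)n4)cc3[nH]1)CO2`, measured in an assay on cells for inhibition of Rho-associated protein kinase 2 (Homo sapiens); on this read-out higher numbers stand for weaker inhibition and lower numbers for stronger inhibition: "not determined" (no result reported)
Compound 2 `c1ccc2c(c1)CC(c1nc3ccc(-c4ccncc4)cc3[nH]1)CO2`, measured in this assay: < 6 nM

Compound 1 has no number of its own in this assay. Among the compounds with values here, the only other value shown belongs to compound 2, whose reading of < 6 nM in this assay is a limit of the assay rather than a number; this is the only evidence at hand (the limit of < 6 nM in this assay, at which 1 of the 2 values shown sits). Compound 3 `COc1ccc2c(c1)CC(c1nc3ccc(-c4ccnc(N)n4)cc3[nH]1)CO2` differs from compound 1 by methyl in place of isopropyl on an oxygen on an aromatic ring. Within the data shown here, with no measured step between compounds that differ in this way, no change beyond the usual scatter is expected in this assay. Compound 3 is estimated at 10 nM, between 2 nM and 50 nM.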

Compound 3, half-maximal inhibitory concentration: 99 nM
Compound 3: the middle estimate sits 9.9-fold (1.00 log units) below what was measured; the measured number lies above the stated range.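

Compound 1 has no number of its own in this assay, so the step from isopropoxy to methoxy between compound 1 and compound 3 cannot be read. Going by these compounds, whether that shortening changes inhibition at all stays open.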